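The compounds below may be only part of what the source reports. "The series", "measured", "known", "first", "only" and "open" are said of these compounds alone.

Of the compounds shown here, two carrying the same core have been measured so far. Compound 1 `Cc1ccc(/N=C2\C(=O)Nc3ccc(S(=O)(=O)N4CCOCC4)cc32)cc1` gives 12800 nM in a functional assay on HepG2 cells (Homo sapiens) for cytotoxicity, read by sulforhodamine B assay, with a stated time of 24 h (on this read-out higher numbers stand for weaker inhibition and lower numbers for stronger inhibition), and on that read-out it shows the lower of the two numbers recorded. Compound 2 `N/N=C1\C(=O)Nc2ccc(S(=O)(=O)N3CCOCC3)cc21` gives 32400 nM in this assay. Among the measured compounds shown here, the single step between them, a 2.5-fold higher number from compound 1 to compound 2 (0.40 log units; beyond the scatter), is the only change at the double-bonded nitrogen that has been measured.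

Compound 3 `O=C1Nc2ccc(S(=O)(=O)N3CCOCC3)cc2/C1=N/Nc1ccccc1` has not yet been measured. It differs from compound 1 in one place: anilino in place of 4-methylphenyl on a double-bonded nitrogen. The step from compound 1 to compound 2 bears on this change, since it also replaces the 4-methylphenyl group on the same nitrogen and it raised the number modestly. The anilino group keeps an aromatic ring where the amino group did not, so the expected effect is smaller than that step, though still upward. For compound 3 an estimated number in this assay of 18000 nM is expected, with a range from 7000 nM to 45000 nM. This estimate corresponds to an expected step of a 1.4-fold higher number from compound 1 to compound 3 (0.15 log units; within the scatter), one that may not stand beyond the scatter.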

Compound 3, half-maximal inhibitory concentration: 15600 nM
Compound 3: the middle estimate sits 1.2-fold (0.06 log units) above what was measured, and the stated range covers the measured number.
By their numbers in this assay, from the lowest: compounds 1 and 3 (each within the scatter of the next); then compound 2.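

In this assay, anilino in place of 4-methylphenyl on a double-bonded nitrogen gives a 1.2-fold higher number from compound 1 to compound 3 (0.09 log units; within the scatter), so placing an amine nitrogen before the aromatic ring leaves the number within the scatter of the directly attached ring. Phenyl in place of hydrogen on the amine nitrogen gives a 2.1-fold lower number from compound 2 to compound 3 (0.32 log units; beyond the scatter), which shows that the step seen earlier with amino can be reversed by restoring an aromatic ring at this position, with compounds 1 and 3 standing together on the lower side of compound 2. No measured information is available to explain either step.

The compounds shown leave open whether an aromatic ring itself is needed on the amine nitrogen, a question that a cyclohexyl or a methyl group there would address by showing whether the number stays near that of compound 3 or that of compound 2. From the compounds shown here alone, it also remains open how a chlorine, a methoxy group or a carboxylic acid on the phenyl ring of the anilino group would shift the number.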